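A Methoxy Step Repeated Across Two Compound Pairs

This account rests on a few compounds, and the source may have more. Where it says the series, first, only, none or still open, it means among the compounds named here.

The account covers three measured compounds and one still to be measured, all tested in a functional assay on OVCAR-3 cells (Homo sapiens) for cytotoxicity, read by sulforhodamine B assay, with a stated time of 48 h, tested at 0.1 uM; on this read-out lower numbers stand for a stronger effect and higher numbers for a weaker effect at the one concentration tested. Compound 3 `COc1ccc(-c2cc(/C=C/C(=O)c3ccc(N)cc3)[nH]n2)cc1OC` gives 108% in this assay. Compound 1 `COc1cc(-c2cc(/C=C/C(=O)c3ccc(N)cc3)[nH]n2)cc(OC)c1OC` differs from compound 3 by methoxy in place of hydrogen on an aromatic carbon; in this assay compound 1 gives 110%, and the step of a number 2 percentage points higher from compound 3 to compound 1 (within the scatter). Compound 2 `COc1ccc(C(=O)/C=C/c2cc(-c3cc(OC)c(OC)c(OC)c3)n[nH]2)cc1OC` gives 100% in this assay, and the step of a number 10 percentage points lower from compound 1 to compound 2 (within the scatter). The difference between the core of compound 2 and the core of compound 3 is not broken down here; their two values simply show readings that lie within the scatter of each other.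

Compound 4 `COc1cc(C(=O)/C=C/c2cc(-c3cc(OC)c(OC)c(OC)c3)n[nH]2)cc(OC)c1OC` is the unmeasured member. It differs from compound 2 by methoxy in place of hydrogen on an aromatic carbon, the same change that separates compound 3 from compound 1, and the surroundings of the place are described in the same words for both pairs. The earlier step, a number 2 percentage points higher from compound 3 to compound 1 (within the scatter), gave no movement beyond the scatter. On that basis, the step expected from compound 2 to compound 4 in this assay is a number 1 percentage points higher from compound 2 to compound 4 (within the scatter), resting on the earlier pair and on the value of compound 2, 100%. Compound 4 is therefore estimated to give 101% in this assay, expected to fall between 88% and 114%.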

Compound 4, a percentage reported as activity, at one concentration (the size of the read-out at that concentration, not a potency): 105%
Estimate against measurement, compound 4: 4 percentage points below; the range from low to high includes it.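

In this assay, methoxy in place of hydrogen on an aromatic carbon gives, on the core of compound 2, a number 5 percentage points higher from compound 2 to compound 4 (within the scatter). Set beside the earlier pair, the same change reads alike on the two cores: the same change on two cores in this assay, a number 2 percentage points higher (within the scatter) from compound 3 to compound 1 and a number 5 percentage points higher (within the scatter) from compound 2 to compound 4, 3 percentage points apart, within the scatter of two such steps Within these two pairs, then, the change carries from one core to the other with no movement that can be told from the scatter, but this shows only that neither core responds to it in a readable way, not that methoxy has any effect of its own, and two pairs read at a single concentration cannot show that the change would behave the same way on other cores, at other concentrations or in other cells.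

The compounds shown have only hydrogen or methoxy at the changed place, so it remains open how a hydroxyl group, a fluorine atom or a longer alkoxy chain there would read on either core. The groups on the carbonyl carbon are limited to 4-aminophenyl and 3,4-dimethoxyphenyl, which leaves open whether the methoxy step would hold with a carboxylic acid or a dimethylamino group on that phenyl ring.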